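Replacing the charged sulfur chain of compound 1 with a hydrazide

A few compounds are considered here, and "the series" means these few. Any claim that something is new, unique, unknown or untested is made for them only; others in the source may bear on it.

Measured in an assay on isolated protein for inhibition of S-adenosylmethionine decarboxylase proenzyme (Homo sapiens); a lower number here means a stronger inhibitor, a higher number a weaker inhibitor:
Compound 1, `Cc1nc2c(N)ncnc2n1[C@@H]1O[C@H](C[S+](C)C)[C@@H](O)[C@H]1O`, gives 3000 nM.
Compound 2, `CN(CCC(=O)NN)C[C@H]1O[C@@H](n2cnc3c(N)ncnc32)[C@H](O)[C@@H]1O`, gives 1500 nM.

Compound 1 shows the higher of the two numbers, but the value of compound 2 lies within the usual scatter of it, so no order between them can be read. Compound 3, `Cc1nc2c(N)ncnc2n1[C@@H]1O[C@H](CN(C)CC(=O)NN)[C@@H](O)[C@H]1O`, keeps the core of compound 1 and differs from it by a group of 7 heavy atoms (3 carbon, 3 nitrogen, 1 oxygen; no ring) in place of a group of 3 heavy atoms (2 carbon, 1 sulfur; no ring), on a saturated chain carbon bound to a saturated ring carbon. For the measured compounds named here, no measured pair isolates this change; compound 2, whose chain carries no sulfur, gives a number close to that of compound 1. The step of a 1.5-fold lower number from compound 1 to compound 3 (0.18 log units; within the scatter) is expected to be small, in no clear direction beyond the scatter. Compound 3 is therefore estimated at 2000 nM, with a range from 500 nM to 8000 nM.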

Compound 3, half-maximal inhibitory concentration: 31000 nM
The estimate for compound 3 lay 16-fold (1.19 log units) below the measured number; measured number above the stated range.
By their numbers in this assay, from the lowest: compounds 2 and 1 (each within the scatter of the next); then compound 3.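

In this assay, the exchange on the saturated chain carbon bound to a saturated ring carbon gives a 10-fold higher number from compound 1 to compound 3 (1.01 log units; beyond the scatter), so on the core of compound 1 this position does not tolerate the change freely. For the compounds shown here, compound 2 differs from compound 1 in more than one place, so this step is the first to put a size on the change at this position. Nothing measured here explains the step.

On these data alone, whether the loss follows the net charge leaving or the hydrazide entering stays open. So does how a simple amine or a carboxylic acid at the end of this chain would read on the same core.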